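Swapping a pyridine ring for a carboxy-methoxyphenyl group

The source may hold more compounds than are shown below. What is called first, only, known or untested is meant among the compounds shown, and "the series" means these compounds.

Compound 3 `Clc1cc(Cl)cc(CO[C@H]2CCCN(Cc3cccnc3)[C@H]2c2ccccc2)c1` gives 112000 nM in an assay on isolated protein for activation of cGMP-dependent protein kinase 1 (Homo sapiens), read by ADP-Glo, with stated times of 120 min and 40 min; on this read-out lower numbers stand for an effect already at smaller amounts and higher numbers for an effect only at larger amounts of compound. Compound 2 `O=C(O)c1cncc(CN2CCC[C@H](OCc3cc(Cl)cc(Cl)c3)[C@@H]2c2ccccc2)c1` gives 117000 nM in this assay, and the step of a 1.0-fold lower number from compound 2 to compound 3 (0.02 log units; within the scatter) is within the scatter. Compound 1 `Clc1cc(Cl)cc(CO[C@H]2CCCN(Cc3ccccn3)[C@H]2c2ccccc2)c1` gives > 200000 nM in this assay, which is a limit and not a number. Compound 4 `COc1ccc(C(=O)O)cc1CN1CCC[C@H](OCc2cc(Cl)cc(Cl)c2)[C@@H]1c1ccccc1` differs from compound 3 by 5-carboxy-2-methoxyphenyl in place of pyridin-3-yl on a saturated chain carbon bound to an amine nitrogen in a ring. For the measured compounds named here, two measured steps touch this change: an at least 1.7-fold lower number from compound 1 to compound 3 (0.25 log units; that floor lies within the scatter) shifted the ring nitrogen, and a 1.0-fold lower number from compound 2 to compound 3 (0.02 log units; within the scatter) removed a carboxy group; neither reached beyond the scatter. For compound 4 a step of a 1.0-fold lower number from compound 3 to compound 4 (0.01 log units; within the scatter) is therefore expected, none beyond the scatter. Compound 4 is estimated at 110000 nM, with a range from 40000 nM to 250000 nM.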

Compound 4, half-maximal effective concentration: 123000 nM
The estimate for compound 4 lay 1.1-fold (0.05 log units) below the measured number, within the range that was stated.
By their numbers in this assay, from the lowest: compounds 3, 2 and 4 (each within the scatter of the next). At a limit, above all of these: compound 1.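

Putting 5-carboxy-2-methoxyphenyl, with 11 heavy atoms in place of 6, on a saturated chain carbon bound to an amine nitrogen in a ring leaves the number within the scatter, with a 1.1-fold higher number from compound 3 to compound 4 (0.04 log units; within the scatter) and a 1.1-fold higher number from compound 2 to compound 4 (0.02 log units; within the scatter). So this position holds a ring of carbon only, carrying both methoxy and carboxy groups, without separating from the pyridine compounds. The remaining step, an at least 1.6-fold lower number from compound 1 to compound 4 (0.21 log units; that floor lies within the scatter), is only a floor, since one end is a limit of the assay: the limit of > 200000 nM in this assay, at which 1 of the 4 values shown sits.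

On these data alone, whether an amide or an amine in place of the carboxy group on this ring would shift the number stays open.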